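Placing compound 4 without a number for compound 3

The source may hold more compounds than are shown below. What is called first, only, known or untested is meant among the compounds shown, and "the series" means these compounds.

Compound 1 `OC[C@H]1O[C@@H](n2cnc3c(NCc4cccc(F)c4)ncnc32)[C@H](O)[C@@H]1O` – 920 nM
Compound 2 `COc1cc(CNc2ncnc3c2ncn3[C@@H]2O[C@H](CO)[C@@H](O)[C@H]2O)cc(OC)c1` – 20200 nM
Compound 3 `OC[C@H]1O[C@@H](n2cnc3c(NCc4cc(O)cc(O)c4)ncnc32)[C@H](O)[C@@H]1O` – "not determined" (no result reported)

In a functional assay on HL-60 cells (Homo sapiens) for antiproliferative activity, with a stated time of 72 h (on this read-out lower numbers stand for stronger inhibition and higher numbers for weaker inhibition), compound 3 has only the entry "not determined" (no result reported) and so holds no place on the scale. Compound 4 `Cc1cccc(CNc2ncnc3c2ncn3[C@@H]2O[C@H](CO)[C@@H](O)[C@H]2O)c1O` differs from compound 3 by 2-hydroxy-3-methylphenyl in place of 3,5-dihydroxyphenyl on a saturated chain carbon bound to a nitrogen on an aromatic ring with 2-hydroxy-3-methylphenyl in place of 3,5-dihydroxyphenyl on a saturated chain carbon bound to a nitrogen on an aromatic ring. Within the data shown here, the only measured step at this place is a 22-fold higher number from compound 1 to compound 2 (1.34 log units; beyond the scatter) and it is large. It shows that the group there can move the read-out, but it does not start from compound 3. No size or direction of step from compound 3 can therefore be expected in this assay at all. Compound 4 is instead expected to fall inside the span set by compound 1 at 920 nM and compound 2 at 20200 nM rather than at either end. The estimate for compound 4 is 3000 nM and the expected range runs from 500 nM up to 18000 nM.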

Compound 4, half-maximal inhibitory concentration: 15000 nM
Estimate against measurement, compound 4: 5.0-fold (0.70 log units) below, within the range that was stated.
By their numbers in this assay, from the lowest: compound 1; then compounds 4 and 2 (each within the scatter of the next).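

In this assay, 2-hydroxy-3-methylphenyl in place of 3-fluorophenyl gives a 16-fold higher number from compound 1 to compound 4 (1.21 log units; beyond the scatter), while in place of 3,5-dimethoxyphenyl it gives a 1.3-fold lower number from compound 2 to compound 4 (0.13 log units; within the scatter). A second, differently substituted phenyl group at this place thus sits with the 3,5-dimethoxyphenyl of compound 2, and of the three measured compounds, only the 3-fluorophenyl of compound 1 stands apart. No evidence at hand explains this.

Steps from compound 3 cannot be read, so the place of 3,5-dihydroxyphenyl stays unknown. On these data alone, whether a chlorophenyl or an aminophenyl group would stay close to compound 1 also remains open.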